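Replacing the 3-oxopiperazin-1-yl amide of compound 3

The source may report more compounds than this note shows. Statements on the series, on what has been measured and on what is new or still open speak of the compounds shown alone.

Values in a functional assay on blood (Homo sapiens), with a stated time of 60 min, in the presence of a further agent that is not named here; a lower number here means that less compound is needed, a higher number that more compound is needed for the effect:
- Compound 1 `O=S(=O)(c1ccc(Oc2ccc(OC(F)(F)F)cc2)cc1)C1CCC2(CCNCC2)C1`: > 15000 nM
- Compound 2 `O=C(Nc1ccccn1)C1(S(=O)(=O)c2ccc(Oc3ccc(OC(F)(F)F)cc3)cc2)CCC2(CCNCC2)C1`: > 15000 nM
- Compound 3 `O=C1CN(C(=O)C2(S(=O)(=O)c3ccc(Oc4ccc(OC(F)(F)F)cc4)cc3)CCC3(CCNCC3)C2)CCN1`: 7500 nM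

Compound 1 and compound 2 both rest at the limit of > 15000 nM in this assay, at which 2 of the 3 values shown sit. Compound 3 alone carries a real number, 7500 nM.

Compound 4 `COc1ccc(N)c(NC(=O)C2(S(=O)(=O)c3ccc(Oc4ccc(OC(F)(F)F)cc4)cc3)CCC3(CCNCC3)C2)c1` has (2-amino-5-methoxyphenyl)amino in place of 3-oxopiperazin-1-yl on a carbonyl carbon. The closest measured step, read in reverse, is an at least 2.0-fold lower number from compound 2 to compound 3 (0.30 log units; that floor lies within the scatter), since compound 2 also has an aromatic ring on its amide nitrogen. The step that the two limits leave unreadable from compound 1 to compound 2 adds nothing on size. A small move towards a higher number is therefore expected, and a result at the limit is possible. The expected step is a 1.3-fold higher number from compound 3 to compound 4 (0.12 log units; within the scatter). Compound 4 is estimated at 10000 nM, with an expected range of 2000 nM to 30000 nM.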

Compound 4, half-maximal effective concentration: 3700 nM
Compound 4: the middle estimate sits 2.7-fold (0.43 log units) above what was measured; the measured number falls inside the stated range.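

In this assay, an aromatic ring on the amide nitrogen is compatible with a gain at this carbonyl carbon: (2-amino-5-methoxyphenyl)amino in place of 3-oxopiperazin-1-yl gives a 2.0-fold lower number from compound 3 to compound 4 (0.31 log units; beyond the scatter). The ring's substituents matter, as 2-amino-5-methoxyphenyl in place of pyridin-2-yl gives an at least 4.0-fold lower number from compound 2 to compound 4 (0.60 log units; beyond the scatter), while adding the whole (2-amino-5-methoxyphenyl)carbamoyl group gives an at least 4.0-fold lower number from compound 1 to compound 4 (0.60 log units; beyond the scatter). Both of these steps are floors, since compound 1 and compound 2 each rest at a limit: the limit of > 15000 nM in this assay, at which 2 of the 4 values shown sit.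

From the compounds shown here alone, it remains open whether the amino group, the methoxy group or both account for the gain, and whether a carboxylic acid in their place would serve equally well.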